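This account rests on a few compounds, and the source may have more. Where it says the series, first, only, none or still open, it means among the compounds named here.

Three compounds of the series have numbers in an assay on a protein complex for inhibition of ubiquitin carboxyl-terminal hydrolase 1/WD repeat-containing protein 48 (Homo sapiens), read by fluorescence; on this read-out lower numbers stand for stronger inhibition and higher numbers for weaker inhibition. Compound 1 `CC(C)c1ccccc1-c1nc2c(c(NCc3ccc(-c4cccnc4)cc3)n1)CCC2` gives 160 nM. Compound 2 `Cc1cnc(-c2ccccc2C(C)C)nc1NCC1CCN(C2COC2)CC1` gives 13600 nM. Compound 3 `Cc1cnc(-c2ccccc2C(C)C)nc1NCC1CCN(c2cnccn2)CC1` gives 140 nM; this number and that of compound 1 sit within the scatter of each other, whereas the number of compound 2 lies far higher, beyond the scatter. For the measured compounds named here, the only single-point step among the measured compounds is a 97-fold lower number from compound 2 to compound 3 (1.99 log units; beyond the scatter), which shows that what sits on the amine nitrogen in the ring moves the number strongly in this assay.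

Compound 4 `Cc1cnc(-c2ccccc2C(C)C)nc1NCC1CCN(c2cccnc2)CC1` is not yet measured. It differs from compound 3 in one place: pyridin-3-yl in place of pyrazin-2-yl on an amine nitrogen in a ring. Going by the values given here, no measured pair isolates this exchange. The step from compound 2 to compound 3 bears on it only indirectly, in that it sets oxetan-3-yl against an aromatic ring at the same place and shows the aromatic ring to go with a low number. Compound 1 carries pyridin-3-yl on a different part of the molecule, and its number is near that of compound 3, which says nothing direct about the ring amine. The expectation is a step of a 1.4-fold higher number from compound 3 to compound 4 (0.15 log units; within the scatter), that is, no change beyond the scatter. Compound 4 is therefore estimated at 200 nM, with a range from 60 nM to 700 nM.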

Compound 4, half-maximal inhibitory concentration: 80 nM
Beside the measured number, compound 4's estimate is 2.5-fold (0.40 log units) above it; low and high end bracket the measured number.
By their numbers in this assay, from the lowest: compounds 4, 3 and 1 (each within the scatter of the next); then compound 2.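

In this assay, for the compounds shown here, the first direct comparison of these two rings on the amine nitrogen in the ring is a 1.8-fold lower number from compound 3 to compound 4 (0.24 log units; within the scatter), so pyridin-3-yl, with 1 hetero atom in its ring, and pyrazin-2-yl, with 2, are not told apart at this position. Against oxetan-3-yl at the same place, the pyridin-3-yl compound gives a 170-fold lower number from compound 2 to compound 4 (2.23 log units; beyond the scatter), which shows that the large step seen earlier is not confined to pyrazin-2-yl: compound 3 and compound 4 both carry a six-membered aromatic ring here, and both lie far from compound 2. No supporting data accompany these numbers to explain either step.

A phenyl ring, with no ring nitrogen, would show whether any ring nitrogen is needed at this position, and a cyclohexyl ring would show whether the ring must be aromatic at all. As far as these compounds go, it also remains open whether pyridin-2-yl or pyridin-4-yl would stay within the scatter of compound 4, so the effect of where the ring nitrogen sits is still unknown.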